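The source may report more compounds than this note shows. Statements on the series, on what has been measured and on what is new or still open speak of the compounds shown alone.

Of the compounds shown here, two have numbers so far. Compound 1 `Cc1cnc(C(=O)Nc2cc(F)cc3cccnc23)cn1` gives 2100 nM in a functional assay on PANC-1 cells (Homo sapiens) for inhibition, read by MTT assay, with a stated time of 72 h; a lower number here means a stronger inhibitor, a higher number a weaker inhibitor. Compound 2 `Cc1cnc(C(=O)Nc2cc(Cl)cc3cccnc23)cn1`, with chloro in place of fluoro on an aromatic carbon, gives 1770 nM in this assay; the step of a 1.2-fold lower number from compound 1 to compound 2 (0.07 log units; within the scatter) is within the scatter, so the two halogens cannot be told apart on these numbers. Compound 2 holds the lowest of the two numbers, with compound 1 nearest, but within the scatter neither is to be called the stronger.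

Compound 3 `O=C(Nc1cc(Cl)cc2cccnc12)c1ncccn1` keeps the chloro of compound 2 and changes the acyl end: pyrimidin-2-yl in place of 5-methylpyrazin-2-yl on a carbonyl carbon. Going by the values given here, no measured step touches this part of the molecule; the only step so far, a 1.2-fold lower number from compound 1 to compound 2 (0.07 log units; within the scatter), concerns the halogen on the other ring and says nothing about the acyl group. The expectation therefore rests on compound 2 alone, and the direction of the step is open; as a cautious working guess a modest rise in the number is assumed, and it is estimated that a 1.7-fold higher number from compound 2 to compound 3 (0.23 log units; within the scatter). Compound 3 is expected to give about 3000 nM in this assay, with a range from 900 nM to 10000 nM.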

Compound 3, half-maximal inhibitory concentration: 4670 nM
Estimate against measurement, compound 3: 1.6-fold (0.19 log units) below; the measured number falls inside the stated range.
By their numbers in this assay, from the lowest: compounds 2 and 1 (each within the scatter of the next); then compound 3.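

Going by these compounds alone, the acyl end is the first place where a single change moves the number beyond the scatter: pyrimidin-2-yl in place of 5-methylpyrazin-2-yl on a carbonyl carbon gives a 2.6-fold higher number from compound 2 to compound 3 (0.42 log units; beyond the scatter) in this assay while the halogen step a 1.2-fold lower number from compound 1 to compound 2 (0.07 log units; within the scatter) stays within it. This position therefore responds even though the counted features of the two groups largely match, each having one six-membered aromatic ring with 2 hetero atoms, 0 hydrogen-bond donors, 2 hydrogen-bond acceptors and no net charge, and only the heavy atoms differing, 7 against 6. No measurement at hand bears on the reason for this rise.

Both the methyl group and the ring itself change in this one step, so the compounds shown cannot say which of the two carries the rise. Also open, on these data alone, are the reading of other groups on the carbonyl carbon, such as a plain phenyl ring or a ring bearing an amine or a carboxylic acid, and whether the step holds with fluoro in place of chloro.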